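Swapping an amide for an amine on a long chain

A few compounds are considered here, and "the series" means these few. Any claim that something is new, unique, unknown or untested is made for them only; others in the source may bear on it.

In a functional assay on SF-539 cells (Homo sapiens) for inhibition, read by sulforhodamine B assay, with a stated time of 48 h (a lower number here means a stronger inhibitor of growth, a higher number a weaker inhibitor of growth), compound 1 (`CCCCCCCCCCCC[C@@H](O)[C@H]1CC[C@H]([C@H](O)CCCCCCCCCCNC(=O)c2ccnn2C)O1`) gives 3720 nM. Compound 2 (`CCCCCCCCCCCC[C@@H](O)[C@H]1CC[C@H]([C@H](O)CCCCCCCCCCN(C)C(=O)c2ccnn2C)O1`) gives 12000 nM, the higher of the two numbers. Compound 3 (`CCCCCCCCCCCC[C@@H](O)[C@H]1CC[C@H]([C@H](O)CCCCCCCCCCNCc2ccnn2C)O1`) alters compound 2 as follows: ((1-methyl-1H-pyrazol-5-yl)methyl)amino in place of methyl((1-methyl-1H-pyrazol-5-yl)carbonyl)amino on a saturated chain carbon, ten or more bonds along the chain from an oxygen on a saturated carbon and a saturated ring carbon. The carbonyl leaves, and the nitrogen carries hydrogen instead of methyl. Among the measured compounds shown here, one measured step bears on this, with methyl in place of hydrogen on an amide-type nitrogen: a 3.2-fold higher number from compound 1 to compound 2 (0.51 log units; beyond the scatter). For the measured compounds named here, no measured step covers losing the carbonyl, so confidence is limited. A modest move to a lower number is expected, an estimated 2.4-fold lower number from compound 2 to compound 3 (0.38 log units; beyond the scatter). The estimate for compound 3 is 5000 nM, with an expected range of 1500 nM to 15000 nM.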

Compound 3, concentration for 50% growth inhibition: 1580 nM
The estimate for compound 3 lay 3.2-fold (0.50 log units) above the measured number; the range from low to high includes it.
By their numbers in this assay, from the lowest: compound 3; then compound 1; then compound 2.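

With (1-methyl-1H-pyrazol-5-yl)methyl in place of (1-methyl-1H-pyrazol-5-yl)carbonyl on the amine nitrogen, a 2.4-fold lower number from compound 1 to compound 3 (0.37 log units; beyond the scatter) appears in this assay, so growth inhibition here does not depend on the carbonyl. Losing the carbonyl and the nitrogen methyl together gives a 7.6-fold lower number from compound 2 to compound 3 (0.88 log units; beyond the scatter) in this assay, which separates the amine of compound 3 from both amides. Nothing available explains these shifts.

Still open, from the compounds shown here alone, is whether a methyl on the amine nitrogen of compound 3 would raise the number, as it does for the amide. Also open, going by these compounds, is how a phenyl ring would compare with the (1-methyl-1H-pyrazol-5-yl) group.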